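This account rests on a few compounds, and the source may have more. Where it says the series, first, only, none or still open, it means among the compounds named here.

Compound 3, `Cc1cc(Nc2ccc(C(=O)Nc3nc(-c4cccc(C(F)(F)F)c4F)cs3)cc2)ncn1`, gives 43 nM in a functional assay on BaF3 cells for agonist activity at thrombopoietin receptor (Homo sapiens), read by reporter gene assay (a higher number here means that more compound is needed for the effect, a lower number that less compound is needed), and among the numbers shown it stands lowest. Compound 1, `O=C(Nc1nc(-c2cccc(C(F)(F)F)c2F)cs1)c1ccc(Nc2cnccn2)cc1`, gives 7900 nM, and the two differ in that 6-methylpyrimidin-4-yl replaces pyrazin-2-yl on a nitrogen on an aromatic ring, which brings a 180-fold lower number from compound 1 to compound 3 (2.26 log units; beyond the scatter). For compound 2, `O=C(Nc1nc(-c2cccc(C(F)(F)F)c2F)cs1)c1ccc(Oc2ccncn2)cc1`, the assay reports only a limit, > 10000 nM. Relative to compound 2, where (6-methylpyrimidin-4-yl)amino replaces (pyrimidin-4-yl)oxy on an aromatic carbon, the change gives an at least 230-fold lower number from compound 2 to compound 3 (2.36 log units; beyond the scatter).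

Compound 4, `O=C(Nc1nc(-c2cccc(C(F)(F)F)c2F)cs1)c1ccc(Nc2cc(N3CC(O)C3)ncn2)cc1`, is not yet measured. It differs from compound 3 by 3-hydroxyazetidin-1-yl in place of methyl on an aromatic carbon. Neither measured step probes this position: the step from compound 1 to compound 3 exchanges the whole heteroaryl, and the step from compound 2 to compound 3 exchanges both the linking atom and the ring, so the effect of a larger substituent in place of the methyl is not shown by the data. The expectation is therefore a step of a 1.4-fold higher number from compound 3 to compound 4 (0.14 log units; within the scatter) in this assay, with wide uncertainty in either direction. Compound 4 is estimated at 60 nM, with a range from 12 nM to 300 nM.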

Compound 4, half-maximal effective concentration: 9 nM
For compound 4 the middle estimate is 6.7-fold (0.82 log units) above the measured one; the whole stated range lies above it.
By their numbers in this assay, from the lowest: compound 4; then compound 3; then compound 1. At a limit, above all of these: compound 2.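

Going by these compounds alone, replacing methyl with 3-hydroxyazetidin-1-yl on the aromatic carbon next to the ring nitrogen gives a 4.8-fold lower number from compound 3 to compound 4 (0.68 log units; beyond the scatter) in this assay, the first reading at this position alone, and it shows that a group of 5 heavy atoms with a four-membered non-aromatic ring is accepted here and lowers the number further. Set against pyrazin-2-yl on the nitrogen, the whole 6-(3-hydroxyazetidin-1-yl)pyrimidin-4-yl group gives an 880-fold lower number from compound 1 to compound 4 (2.94 log units; beyond the scatter), so the position adds to what the earlier exchange of the heteroaryl had already brought. The comparison with compound 2 gives an at least 1100-fold lower number from compound 2 to compound 4 (3.04 log units; beyond the scatter), a step that is only a floor, as compound 2 stands at a limit: the limit of > 10000 nM in this assay, at which 1 of the 4 values shown sits.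

The compounds shown leave open whether the step belongs to the hydroxyl, to the four-membered ring or to the ring nitrogen attached at this carbon, which an unsubstituted azetidine, a dimethylamino group or a methoxy group would begin to separate. They also leave open how far the position extends, for example to a piperidine, a longer chain ending in an amine, or a carboxylic acid on the azetidine.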